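This account rests on a few compounds, and the source may have more. Where it says the series, first, only, none or still open, it means among the compounds named here.

Measured so far, in an assay on CHO cells for antagonist activity at transient receptor potential cation channel subfamily V member 1 (Homo sapiens), read by FLIPR; a higher number here means a weaker inhibitor, a lower number a stronger inhibitor:
- compound 1, `CC(C(=O)NCc1ccc(C(F)(F)F)nc1-c1ccsc1)c1ccc(NS(C)(=O)=O)c(F)c1`, compound 1 gives 2 nM
- compound 2, `Cc1ccc(CCc2nc(C(F)(F)F)ccc2CNC(=O)C(C)c2ccc(NS(C)(=O)=O)c(F)c2)cc1`, compound 2 gives 0.6 nM

Among the measured compounds shown here, compound 2 holds the lower of the two numbers in this assay; the only other measured compound, compound 1, sits higher by the step of a 3.3-fold lower number from compound 1 to compound 2 (0.52 log units; beyond the scatter), which came from exchanging thiophen-3-yl for 2-(4-methylphenyl)ethyl on the shared core.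

Compound 3, `CC(C(=O)NCc1ccc(C(F)(F)F)nc1CCc1ccc(F)cc1)c1ccc(NS(C)(=O)=O)c(F)c1`, is the next compound, not yet measured. The change from compound 2 is fluoro in place of methyl on an aromatic carbon of the six-membered carbon-only ring, para to a large group, so the 2-(4-methylphenyl)ethyl arm becomes 2-(4-fluorophenyl)ethyl.

For the measured compounds named here, no measured step touches this small exchange. Going by the values given here, the one step known, a 3.3-fold lower number from compound 1 to compound 2 (0.52 log units; beyond the scatter), replaced the whole ring at that position and was only modest, so a swap of one atom at the far end of the same arm is expected to move the number little, most likely staying within the scatter. The estimate for compound 3 in this assay is 0.8 nM, expected to fall between 0.3 nM and 2.5 nM, a step of a 1.3-fold higher number from compound 2 to compound 3 (0.12 log units; within the scatter).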

Compound 3, inhibition constant: 1.8 nM
Compound 3: middle estimate off by 2.3-fold (0.35 log units), on the low side; low and high end bracket the measured number.
By their numbers in this assay, from the lowest: compound 2; then compounds 3 and 1 (each within the scatter of the next).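

In this assay, the far end of the arm turns out to matter: exchanging just one atom, methyl for fluoro, gives a 3.0-fold higher number from compound 2 to compound 3 (0.48 log units; beyond the scatter) and counts as a modest step, just as replacing the whole ring did with a 3.3-fold lower number from compound 1 to compound 2 (0.52 log units; beyond the scatter) in the earlier comparison. The 2-(4-fluorophenyl)ethyl arm also cannot be told apart from thiophen-3-yl, as shown by a 1.1-fold lower number from compound 1 to compound 3 (0.05 log units; within the scatter) and its place within the scatter, so among these three compounds the arm alone does not carry the advantage of compound 2; that advantage appears only with the methyl at its end. Nothing measured here explains why methyl and fluoro differ at this place.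
Still open, as far as these compounds go, is whether a hydrogen, a chloro, a methoxy or an ethyl at the same place on the ring would give a number closer to that of compound 2 or of compound 3. It is also unclear whether the methyl would keep its advantage on a longer chain, such as a 3-(4-methylphenyl)propyl arm.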